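A bromo for trifluoromethyl swap on a triazole-linked aryl

The source may hold more compounds than are shown below. What is called first, only, known or untested is meant among the compounds shown, and "the series" means these compounds.

Going by the values given here, compound 1, with the structure `C=C1C(=O)[C@]23C[C@@]1(O)CC[C@H]2c1ccc(O)c(C)c1[C@@H]3Cn1cc(-c2ccc(C(F)(F)F)cc2)nn1`, is the only member of this set with a numeric reading: in a functional assay on SMMC-7721 cells (Homo sapiens) for cytotoxicity, read by MTT assay, with a stated time of 4 days (a higher number here means a weaker inhibitor, a lower number a stronger inhibitor), compound 1 gives 1440 nM. Among the compounds with values here, the other measured member, compound 2, has the structure `Cc1ccc(-c2cn(C[C@H]3c4c(ccc(O)c4C)[C@@H]4CC[C@@]5(C)C[C@]43CC5=O)nn2)cc1` and differs from compound 1 in several places at once, so no single step between them is drawn. In this assay compound 2 reaches only a limit, > 20000 nM, and not a number; this is the limit of > 20000 nM in this assay, at which 1 of the 2 values shown sits. Beyond that, the two values show only that compound 1 returns a number where compound 2 does not.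

The unmeasured compound 3 has the structure `C=C1C(=O)[C@]23C[C@@]1(O)CC[C@H]2c1ccc(O)c(C)c1[C@@H]3Cn1cc(-c2ccc(Br)cc2)nn1`. It differs from compound 1 in one place: bromo in place of trifluoromethyl on an aromatic carbon. The change sits on an aromatic carbon of a six-membered aromatic ring of carbon only, para to a large group, and is told in full by the printed difference. Within the data shown here, with no measured step of this kind to lean on, the step of a 1.1-fold higher number from compound 1 to compound 3 (0.05 log units; within the scatter) is expected to stay within the usual scatter, in no particular direction. Compound 3 is therefore estimated at 1600 nM, with a range from 500 nM to 5000 nM.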

Compound 3, half-maximal inhibitory concentration: 1300 nM
Compound 3: the middle estimate sits 1.2-fold (0.09 log units) above what was measured, and the stated range covers the measured number.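

In this assay, bromo in place of trifluoromethyl on an aromatic carbon, para to a large group, gives a 1.1-fold lower number from compound 1 to compound 3 (0.04 log units; within the scatter). Going by these compounds alone, this is the first step in the set that differs in one place, and it shows that the 4-(trifluoromethyl)phenyl and 4-bromophenyl forms read alike on the core of compound 1, even though the 4 heavy atoms of trifluoromethyl give way to the 1 heavy atom of bromo. The earlier compounds shown here could not show this, as compound 1 and compound 2 differ in several places at once and so give no reading for this position alone.

The compounds shown leave open whether an amine, a carboxylic acid, a methoxy group or a longer chain at this position would read alike too, and whether bare hydrogen there would keep the reading, so one step within the scatter marks no trend for the position as a whole. Nothing measured in the set gives a reason why these two groups read alike.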